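Moving the acetyl group: compound 2 to compound 3

The source may hold more compounds than are shown below. What is called first, only, known or untested is meant among the compounds shown, and "the series" means these compounds.

In an ADME assay on HEK293 cells (Homo sapiens) for cytotoxicity, read by MTT assay, with a stated time of 48 h (a lower number here means a stronger inhibitor, a higher number a weaker inhibitor), compound 1 (`C#CC1=CC[C@@]2(C)C(=C)CCC[C@]2(C)CC1`) gives 524000 nM. Compound 2 (`C=C1CCC[C@]2(C)CCC(c3cn(-c4ccc(C(C)=O)cc4)nn3)=CC[C@@]12C`) gives 520000 nM, so the two compounds stand level within the scatter. Compound 3 (`C=C1CCC[C@]2(C)CCC(c3cn(-c4ccccc4C(C)=O)nn3)=CC[C@@]12C`) carries 2-acetylphenyl in place of 4-acetylphenyl on an aromatic nitrogen of a five-membered aromatic ring with 3 nitrogen: 2-acetylphenyl in place of 4-acetylphenyl on an aromatic nitrogen. Among the measured compounds shown here, no measured pair differs in one place only, so the series offers no direct guide to the size of this step. No shift beyond the scatter is expected in this assay, in either direction. This expectation rests on compound 1 at 524000 nM and compound 2 at 520000 nM, which stand level although only compound 2 carries an acetylphenyl group. The estimated step of a 1.0-fold lower number from compound 2 to compound 3 (0.02 log units; within the scatter) stays within the scatter. The expected value for compound 3 is 500000 nM, with an estimated range of 200000 nM to 1000000 nM.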

Compound 3, half-maximal inhibitory concentration: 524000 nM
For compound 3 the middle estimate is 1.0-fold (0.02 log units) below the measured one; measured number inside the range.
By their numbers in this assay, from the lowest: compounds 2, 1 and 3 (each within the scatter of the next).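

In this assay, among the compounds shown here, the change from 4-acetylphenyl to 2-acetylphenyl gives a 1.0-fold higher number from compound 2 to compound 3 (0.00 log units; within the scatter) and provides the first pair that differs in one place only. On the aromatic nitrogen of the five-membered ring, these two placements of the acetyl group on the phenyl ring therefore stand level within the scatter. No measurement shown gives a reason for this level result.

From the compounds shown here alone, whether an amine or a carboxylic acid in place of the acetyl group on the phenyl ring would also stay level with compound 2 remains open. Going by these compounds, it is equally open whether a longer chain in place of the whole acetylphenyl group on the aromatic nitrogen would move the number beyond the scatter.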